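Halogen swap on the aryl urea of compound 1

A few compounds are considered here, and "the series" means these few. Any claim that something is new, unique, unknown or untested is made for them only; others in the source may bear on it.

Compound 1 `O=C(Nc1ccc(I)cc1)Nn1c(-c2ccccc2)nc2ccccc2c1=O` carries the largest of the three numbers in a functional assay on the whole organism (strain albino) with Mus musculus as the target, at a dose of 100 mg/kg by the intraperitoneal route (on this read-out lower numbers stand for less inhibition and higher numbers for more inhibition at the one dose given (going by the name of the read-out)), giving 60%. Compound 2 `CCc1nc2ccccc2c(=O)n1NC(=O)Nc1ccc(Cl)cc1` gives 52% and compound 3 `CCc1nc2ccccc2c(=O)n1NC(=O)Nc1ccc(F)cc1` gives 51%; both gaps to compound 1 fall within the scatter, so the three measured compounds cannot be ranked on these numbers. Within the data shown here, the one measured step that exchanges only a halogen, a number 1 percentage points lower from compound 2 to compound 3 (within the scatter), likewise stays within the scatter. Compound 4 `O=C(Nc1ccc(Br)cc1)Nn1c(-c2ccccc2)nc2ccccc2c1=O` differs from compound 1 in one place: bromo in place of iodo on an aromatic carbon. This change is of the same kind as the measured step, one halogen in place of another on an aromatic carbon, so the expectation for compound 4 in this assay is a step of about a number 2 percentage points lower from compound 1 to compound 4 (within the scatter), that is no movement beyond the scatter. Compound 4 is therefore estimated at 58%, with a range from 42% to 74%. Among the measured compounds shown here, since only one bearing step exists, and it comes from a different pair of compounds, the range is kept wide.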

Compound 4, a percentage reported as inhibition, in the whole organism at one dose (the size of the read-out at that dose, not a potency): 58%
Beside the measured number, compound 4's estimate shows no gap at the digits printed; measured number inside the range.
By their numbers in this assay, from the lowest: compounds 3, 2, 4 and 1 (each within the scatter of the next).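

In this assay, among these compounds, the exchange of iodo for bromo on the aryl urea reads as a number 2 percentage points lower from compound 1 to compound 4 (within the scatter), the first step at this place on the parent of compound 1. Among the compounds shown here, the only earlier halogen step, a number 1 percentage points lower from compound 2 to compound 3 (within the scatter), came from a different parent, so two separate pairs now show a halogen exchange on this aromatic carbon, para to a large group, staying within the scatter. Nothing measured on these compounds accounts for this result.

On these data alone, whether a group other than a halogen at this place, such as methoxy, an amine or a carboxylic acid, would move the number beyond the scatter remains open. Also open is how iodo and bromo would read on the parent of compound 2, which is shown only with chloro and fluoro.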